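A few compounds are considered here, and "the series" means these few. Any claim that something is new, unique, unknown or untested is made for them only; others in the source may bear on it.

Two nucleoside analogues share a common core and differ at two places. Compound 1 `NC(=O)c1ncn(C2O[C@H](CO)[C@@H](O)[C@H]2O)c1C#CCCO` carries a carboxamide and a 4-hydroxybut-1-yn-1-yl chain; in a functional assay on L1210 cells (Mus musculus) for inhibition (on this read-out higher numbers stand for weaker inhibition and lower numbers for stronger inhibition), compound 1 gives 1.28 ug/mL. Compound 2 `N#Cc1ncn(C2O[C@H](CO)[C@@H](O)[C@H]2O)c1C#CCO` carries a nitrile and a 3-hydroxyprop-1-yn-1-yl chain; in this assay compound 2 gives 4.1 ug/mL, the higher of the two numbers, and its gap to compound 1 lies beyond the usual scatter. As the two compounds differ in two places, the numbers alone do not tell which difference carries the gap.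

Compound 3 `N#Cc1ncn(C2O[C@H](CO)[C@@H](O)[C@H]2O)c1C#CCCO` keeps the nitrile of compound 2 and changes only the chain: hydroxymethyl in place of hydroxy on a saturated chain carbon bound to a triple-bonded carbon. With no single-change comparison at hand, the step is expected to be small, at most a modest move toward a lower number, in line with the shorter chain sitting in compound 2 at 4.1 ug/mL. The expected step from compound 2 to compound 3 is a 1.6-fold lower number from compound 2 to compound 3 (0.21 log units; within the scatter). Compound 3 is therefore estimated at 2.5 ug/mL, within a range from 0.8 ug/mL to 8 ug/mL.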

Compound 3, half-maximal inhibitory concentration: 3.3 ug/mL
Estimate against measurement, compound 3: 1.3-fold (0.12 log units) below, within the range that was stated.
By their numbers in this assay, from the lowest: compound 1; then compounds 3 and 2 (each within the scatter of the next).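

With the nitrile held fixed, the step from the 3-hydroxyprop-1-yn-1-yl chain to the 4-hydroxybut-1-yn-1-yl chain, read on its own in this assay, is a 1.2-fold lower number from compound 2 to compound 3 (0.09 log units; within the scatter), so this change of chain gives no distinction on this read-out. With the chain held fixed, the change from carboxamide to nitrile is a 2.6-fold higher number from compound 1 to compound 3 (0.41 log units; beyond the scatter), which places a step beyond the scatter at the aromatic carbon, something the two earlier compounds could not separate from the change of chain. Nothing at hand explains either step.

The compounds shown leave open whether the chain change would read the same with the carboxamide in place of the nitrile. They also leave open what a longer chain, an amine in place of the hydroxy, or a carboxylic acid in place of the carboxamide would give.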